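Series notes: amide nitrogen substitution and cytotoxicity

The source may hold more compounds than are shown below. What is called first, only, known or untested is meant among the compounds shown, and "the series" means these compounds.

Measured so far, in an ADME assay on HEK293 cells (Homo sapiens) for cytotoxicity, with a stated time of 6 h; on this read-out lower numbers stand for higher toxicity in this test and higher numbers for lower toxicity in this test:
- compound 1 `CCCCNc1nc(N)nc2cccc(Cl)c12` gives 100 nM.
- compound 2 `CCCCNc1nc(N)nc2cccc(C(=O)NC)c12` is reported only as a limit of the assay, > 25000 nM.

Compound 2 thus sits at the upper edge of what has been measured: no number is known for it, only the limit (the limit of > 25000 nM in this assay, at which 1 of the 2 values shown sits). Among the compounds with values here, the single measured step, an at least 250-fold higher number from compound 1 to compound 2 (2.39 log units; beyond the scatter), moved the read-out from a numbered value into that limit.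

Compound 3 `CCCCNc1nc(N)nc2cccc(C(=O)N(C)C(C)C)c12` differs from compound 2 by isopropyl in place of hydrogen on an amide-type nitrogen. Within the data shown here, no measured step touches the amide-type nitrogen; the one step in hand concerns the replacement on the aromatic carbon and bears on the present change only in that it places compound 2 at the limit. With nothing to argue for a shift, the expectation for this assay is a step of no more than the scatter, a number no higher from compound 2 to compound 3 (the limit leaves the size open), and most likely a second limit rather than a number. Compound 3 is therefore estimated at 25000 nM, with a range from 8000 nM to 100000 nM.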

Compound 3, half-maximal cytotoxic concentration: > 25000 nM
Compound 3 was reported as a limit; the forecaster's own chance of this, stated with the estimate: 70%; the middle value lies on the limit itself.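

In this assay compound 3 is reported only as a limit, > 25000 nM, so the read-out stays outside the numbered range with isopropyl on the amide-type nitrogen. Placing isopropyl(methyl)carbamoyl instead of chloro on the aromatic carbon gives an at least 250-fold higher number from compound 1 to compound 3 (2.39 log units; beyond the scatter), so the large step first seen with methylcarbamoyl on this carbon does not depend on keeping the amide hydrogen. The size of the change on the amide-type nitrogen itself cannot be read, as both amides stand at the same limit: the limit of > 25000 nM in this assay, at which 2 of the 3 values shown sit.

As far as these compounds go, how far beyond the limit either amide lies remains unknown, so no order can be given between them, and the series does not yet show how much substitution on the amide-type nitrogen this position tolerates before a number returns. Also open, from the compounds shown here alone, is whether the unsubstituted carbamoyl, a carboxylic acid or an aminomethyl group on the same aromatic carbon, or a longer chain or a phenyl ring on the amide-type nitrogen, would stay at the limit or bring the read-out back towards the value of compound 1.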